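The source may report more compounds than this note shows. Statements on the series, on what has been measured and on what is new or still open speak of the compounds shown alone.

Measured compounds:
compound 1 `COc1ncnc2c1c(-c1ccsc1)cn2[C@@H]1O[C@H](CO)[C@@H](O)[C@H]1O` — 120 nM
compound 2 `O=c1[nH]cnc2c1c(-c1ccoc1)cn2[C@@H]1O[C@H](CO)[C@@H](O)[C@H]1O` — 10300 nM
compound 3 `CSc1ncnc2c1c(-c1ccccc1)cn2[C@@H]1O[C@H](CO)[C@@H](O)[C@H]1O` — > 20000 nM (a limit)

Of the compounds shown here, three sharing one core have been tested in a functional assay on HCT-116 cells (Homo sapiens), read by MTT assay, with a stated time of 72 h; a higher number here means a weaker inhibitor, a lower number a stronger inhibitor. Compound 1 gives 120 nM. Compound 2 gives 10300 nM, the higher of the two numbers reported, and its gap to compound 1 lies well beyond the scatter. For compound 3 the assay reports only a limit, > 20000 nM, not a number; the limit is noted as the limit of > 20000 nM in this assay, at which 1 of the 3 values shown sits.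

Compound 4 `O=c1[nH]cnc2c1c(-c1cccs1)cn2[C@@H]1O[C@H](CO)[C@@H](O)[C@H]1O` differs from compound 2 in one place: thiophen-2-yl in place of furan-3-yl on an aromatic carbon. For the measured compounds named here, no pair of measured compounds differs in exactly this way, so the size of the step has to be estimated rather than read from the data. Compound 2 stands far from compound 1, but the two differ in more than one place, so that gap cannot be assigned to the five-membered ring alone. The step from compound 2 to compound 4 is expected to be modest, a 1.7-fold lower number from compound 2 to compound 4 (0.23 log units; within the scatter), leaning toward a lower number. Compound 4 is therefore estimated at 6000 nM, within a range from 1500 nM to 25000 nM.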

Compound 4, half-maximal inhibitory concentration: > 20000 nM
Compound 4 ended at the assay's limit (the forecaster's own chance of this, stated with the estimate: 20%); middle value at least 3.3-fold (0.52 log units) away from the limit.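

For the compounds shown here, this is the first step that can be read at this position, where the five-membered ring bound through an aromatic carbon is the only thing that changes: in this assay, thiophen-2-yl in place of furan-3-yl gives an at least 1.9-fold higher number from compound 2 to compound 4 (0.28 log units; that floor lies within the scatter). Compound 4 has only a limit, > 20000 nM, not a number, so the step has a floor but no measured size, and the change brings no lower number on this core. The true distance between the two rings therefore stays hidden, and the readout of this series now often stops at the same point: the limit of > 20000 nM in this assay, at which 2 of the 4 values shown sit.

The compounds shown leave open how the number would move with an amine or a carboxylic acid on this aromatic carbon. They also leave open whether thiophen-2-yl would give the same result with the methoxy group of compound 1 in place of the carbonyl of compound 4.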